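This account rests on a few compounds, and the source may have more. Where it says the series, first, only, none or still open, it means among the compounds named here.

Measured so far:
compound 1 `CCCS(=O)(=O)Nc1cccc2c1CCC2c1ncc[nH]1` gives 54%
compound 2 `c1ccc2c(c1)CCCC2c1ncc[nH]1` gives 71%

Both were tested in a functional assay on CHO cells for agonist activity at Alpha-1A adrenergic receptor (Homo sapiens), read by FLIPR and calcium flux; on this read-out higher numbers stand for larger maximal responses and lower numbers for smaller maximal responses. Compound 1 has the lower of the two numbers; compound 2 stands higher by more than the usual scatter. Compound 3 `CCS(=O)(=O)Nc1cccc2c1CCC2c1ncc[nH]1` differs from compound 1 in one place only: hydrogen in place of methyl on a saturated chain carbon, two bonds along the chain from a sulfonyl sulfur. Among the measured compounds shown here, no measured pair shows what this change does. The step from compound 1 to compound 3 is therefore expected to stay within the scatter, with no clear direction, as the expected step of a number 1 percentage points higher from compound 1 to compound 3 (within the scatter) shows. For compound 3 the estimated largest response in this assay is 55%, with a range from 35% to 75%.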

Compound 3, largest response reached (Emax), in percent of the reference or control that the assay uses: 86%
Estimate against measurement, compound 3: 31 percentage points below, outside the stated range (above it).
By their numbers in this assay, from the lowest: compound 1; then compound 2; then compound 3.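

In this assay, replacing propylsulfonyl with ethylsulfonyl gives a number 32 percentage points higher from compound 1 to compound 3 (beyond the scatter). This shows that the end of the chain on the sulfonyl sulfur is not a silent position: losing a single methyl carbon there is enough to change the maximal response clearly. Nothing measured here explains why the response changes at this position.

The compounds shown leave open what a still shorter methylsulfonyl group or a longer butylsulfonyl chain would do. They also leave open the effect of an amine at the end of the chain.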